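The source may report more compounds than this note shows. Statements on the series, on what has been measured and on what is new or still open speak of the compounds shown alone.

The measured compounds are these. Compound 1, `O=C(NNc1ccccc1Cl)c1ccc(NS(=O)(=O)c2cnc(O)nc2O)cc1`, gives 3340 nM in a functional assay on A549 cells (Homo sapiens) for antiproliferative activity, read by MTT assay, with a stated time of 24 h; on this read-out lower numbers stand for stronger inhibition and higher numbers for weaker inhibition. Compound 2, `O=C(NNc1ccc(F)cc1)c1cccc(NS(=O)(=O)c2cnc(O)nc2O)c1`, gives in this assay only a limit, > 20000 nM. Compound 3, `O=C(NNc1ccc(F)cc1)c1ccccc1NS(=O)(=O)c1cnc(O)nc1O`, likewise gives in this assay only a limit, > 20000 nM.

For the measured compounds named here, compound 1 therefore stands alone: it is the one compound of the three for which this assay returned an actual number. The other two sit at the limit of > 20000 nM in this assay, at which 2 of the 3 values shown sit, so there is no measured step between any pair of these compounds to lean on.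

Compound 4, `O=C(NNC(=O)c1ccc(NS(=O)(=O)c2cnc(O)nc2O)cc1)c1ccc(F)cc1`, has not yet been measured. It differs from compound 1 in one place: (4-fluorophenyl)carbonyl in place of 2-chlorophenyl on an amine nitrogen. The hydrazide part thus changes from an aryl-substituted to an acyl-substituted one, while the rest of the shared core stays as it is.

Going by the values given here, with no comparable step measured, the expectation rests on compound 1 alone and on the size of this change. The step of a 1.8-fold higher number from compound 1 to compound 4 (0.25 log units; within the scatter) in this assay is expected to be a mild weakening, not far beyond the usual scatter. Compound 4 is accordingly estimated at about 6000 nM, with a range from 1500 nM to 20000 nM, and with a real chance that this assay again reports only a limit.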

Compound 4, half-maximal inhibitory concentration: > 20000 nM
Compound 4: only a limit was reported (the forecaster's own chance of this, stated with the estimate: 35%); middle value at least 3.3-fold (0.52 log units) away from the limit.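

For the compounds shown here, this is the first measured step at this position, and it is not a neutral one: with (4-fluorophenyl)carbonyl in place of 2-chlorophenyl on an amine nitrogen, this assay shows an at least 5.9-fold higher number from compound 1 to compound 4 (0.77 log units; beyond the scatter). The shared core stays the same across this pair, so the difference traces to this one place, and the group on that nitrogen clearly matters to the read-out. The value of compound 4 is a limit and not a number, so the step gives only a minimum size, and compound 4 joins the other compounds there: the limit of > 20000 nM in this assay, at which 3 of the 4 values shown sit.

This one change brings in a carbonyl and also replaces a chlorine with a fluorine, and the compounds shown do not separate the two. On these data alone, it also stays open what a plain phenyl or a small acetyl group would do on the same nitrogen, and whether any group there could improve on compound 1, at 3340 nM.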